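Amide aryl swap on the methoxyquinoline ether series

A few compounds are considered here, and "the series" means these few. Any claim that something is new, unique, unknown or untested is made for them only; others in the source may bear on it.

Of the compounds shown here, three of the shared core are measured so far. In a physicochemical assay for lipophilicity, read by HPLC, in phosphate buffer, measured as chromatographic lipophilicity, at pH 7.4 (a higher number here means a more lipophilic compound, a lower number a more polar compound), compound 1 `COc1ccc2nc(C)cc(OCC(=O)Nc3cc(C)cc(C)c3)c2c1` gives 5.64, compound 2 `COc1ccc2nc(C)cc(OCC(=O)Nc3cccc(C)c3)c2c1` gives 4.83 and compound 3 `COc1ccc2nc(C)cc(OCC(=O)Nc3ccc(Cl)cc3Cl)c2c1` gives 6.4. Compound 3 stands highest of the three, with the nearest number at compound 1 and the furthest at compound 2; the steps read a number 0.76 log units higher from compound 1 to compound 3 (beyond the scatter) and a number 1.57 log units higher from compound 2 to compound 3 (beyond the scatter). Among the measured compounds shown here, the single methyl step, a number 0.81 log units lower from compound 1 to compound 2 (beyond the scatter), is modest.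

Compound 4 `COc1ccc2nc(C)cc(OCC(=O)Nc3nc(C)c(C)s3)c2c1` has not been measured. The change is 4,5-dimethyl-1,3-thiazol-2-yl in place of 2,4-dichlorophenyl on an amide-type nitrogen. Both steps that alter the group on the amide-type nitrogen moved this assay by a modest to large amount, and the entering group carries two hydrogen-bond acceptors where the leaving group carried none, so a downward step beyond the scatter is expected. Compound 4 is estimated at 4.6, within 3.9 to 5.3. The step this expectation implies is a number 1.80 log units lower from compound 3 to compound 4 (beyond the scatter), which is expected to bring compound 4 close to the region of compound 2, 4.83.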

Compound 4, distribution coefficient: 4.24
Estimate against measurement, compound 4: 0.36 log units above, within the range that was stated.
By their numbers in this assay, from the lowest: compound 4; then compound 2; then compound 1; then compound 3.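

In this assay, among the compounds shown here, the series shows a number 2.16 log units lower from compound 3 to compound 4 (beyond the scatter) and this is the largest step so far at the amide-type nitrogen. The position is therefore not confined to the spread of the three phenyl-bearing compounds: 4,5-dimethyl-1,3-thiazol-2-yl also gives a number 0.59 log units lower from compound 2 to compound 4 (beyond the scatter) and a number 1.40 log units lower from compound 1 to compound 4 (beyond the scatter) and so places compound 4 lowest of the four. Nothing at hand gives a cause for these steps.

No pair shown separates the part played by the two hetero atoms of the ring from that of its two methyl groups, so an unsubstituted 1,3-thiazol-2-yl would be the informative comparison. As far as these compounds go, how a phenyl ring carrying an amine or a carboxylic acid would read in this assay also stays open.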